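Replacing 3,4-dimethoxyphenyl with 1H-indol-3-yl in compound 4

This account rests on a few compounds, and the source may have more. Where it says the series, first, only, none or still open, it means among the compounds named here.

Of the compounds shown here, three sharing one core have been measured in a functional assay on MGC-803 cells (Homo sapiens) for cytotoxicity, read by MTT assay, with a stated time of 72 h; a higher number here means a weaker inhibitor, a lower number a stronger inhibitor. Compound 1 `COc1cccc(C=C2C(=O)N(c3ccc(Cl)cc3)N(c3ccc(Cl)cc3)C2=O)c1O` gives 24300 nM and compound 2 `O=C1C(=Cc2cccc(Cl)c2)C(=O)N(c2ccc(Cl)cc2)N1c1ccc(Cl)cc1` gives 14400 nM, with a 1.7-fold lower number from compound 1 to compound 2 (0.23 log units; within the scatter). Compound 3 `COc1ccc(C=C2C(=O)N(c3ccc(Cl)cc3)N(c3ccc(Cl)cc3)C2=O)cc1OC` gives only a limit, > 128000 nM.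

Compound 4 `O=C1C(=Cc2c[nH]c3ccccc23)C(=O)N(c2ccc(Cl)cc2)N1c1ccc(Cl)cc1` differs from compound 3 by 1H-indol-3-yl in place of 3,4-dimethoxyphenyl on a double-bonded chain carbon bound to a double-bonded ring carbon. Within the data shown here, all the measured steps concern this same place. Leaving 3,4-dimethoxyphenyl behind is the reverse of an at least 5.2-fold higher number from compound 1 to compound 3 (0.72 log units; beyond the scatter) and of an at least 8.8-fold higher number from compound 2 to compound 3 (0.94 log units; beyond the scatter), so a move down from the limit is expected, of at least modest size. Among the measured compounds shown here, no measured compound carries 1H-indol-3-yl, so this expectation is loose. The expected change is an at least 5.8-fold lower number from compound 3 to compound 4 (0.76 log units; beyond the scatter). The estimated value for compound 4 is 22000 nM, with an expected range from 6000 nM to 80000 nM.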

Compound 4, half-maximal inhibitory concentration: 21800 nM
For compound 4 the middle estimate is 1.0-fold (0.00 log units) above the measured one, within the range that was stated.
By their numbers in this assay, from the lowest: compounds 2, 4 and 1 (each within the scatter of the next). At a limit, above all of these: compound 3.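

In this assay, 1H-indol-3-yl is the only group shown at this place with a five-membered aromatic ring, and it moves clear of the limit, with an at least 5.8-fold lower number from compound 3 to compound 4 (0.76 log units; beyond the scatter). Against the other two groups it shows no readable difference, with a 1.5-fold higher number from compound 2 to compound 4 (0.18 log units; within the scatter) and a 1.1-fold lower number from compound 1 to compound 4 (0.05 log units; within the scatter); 3-chlorophenyl, 2-hydroxy-3-methoxyphenyl and 1H-indol-3-yl therefore sit together, and compound 3 alone stands apart. The full size of the first step stays unknown because compound 3 gives only a limit: the limit of > 128000 nM in this assay, at which 1 of the 4 values shown sits.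

The compounds shown leave open whether the indole nitrogen hydrogen counts for anything here, and whether an amine or a carboxylic acid at this place would stay with these three groups. Nor do they tell what sets 3,4-dimethoxyphenyl apart: 2-hydroxy-3-methoxyphenyl also carries a methoxy group and sits with the others.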